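The source may hold more compounds than are shown below. What is called first, only, known or untested is meant among the compounds shown, and "the series" means these compounds.

compound 1 `CCOC(=O)C1=Cc2ccccc2OC1(OCc1cn(-c2ccccc2)nn1)C(F)(F)F` — > 150000 nM
compound 2 `CCOC(=O)C1=Cc2ccccc2OC1(OCc1cc(-c2ccc(Cl)cc2)no1)C(F)(F)F` — 12300 nM

In a functional assay on HeLa cells (Homo sapiens) for inhibition, read by MTT assay, with a stated time of 24 h (a higher number here means a weaker inhibitor, a lower number a stronger inhibitor), compound 1 gives > 150000 nM, a limit of the assay and not a number. Where compound 1 stands is given only by the limit of > 150000 nM in this assay, at which 1 of the 2 values shown sits. In this assay compound 2 gives 12300 nM. Compound 3 `CCOC(=O)C1=Cc2ccccc2OC1(OCc1cn(CC(=O)NC2CCCCC2)nn1)C(F)(F)F` is not yet measured; it differs from compound 1 by (cyclohexylcarbamoyl)methyl in place of phenyl on an aromatic nitrogen. Within the data shown here, no measured pair shares this change, so the series gives no step to read the direction from. A modest move away from the limit toward a stronger inhibitor in this assay is expected, though it may not exceed the scatter. Compound 3 is estimated at 90000 nM (range 20000 nM to 300000 nM), which means an expected step of an at least 1.6-fold lower number from compound 1 to compound 3 (0.22 log units; that floor lies within the scatter).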

Compound 3, half-maximal inhibitory concentration: 11400 nM
Estimate against measurement, compound 3: 7.9-fold (0.90 log units) above, and the stated range ends above it.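

In this assay, the group on this aromatic nitrogen clearly matters: (cyclohexylcarbamoyl)methyl in place of phenyl gives an at least 13-fold lower number from compound 1 to compound 3 (1.11 log units; beyond the scatter). Compound 1 stands at a limit and not a number, so the true size of this step remains unknown: the limit of > 150000 nM in this assay, at which 1 of the 3 values shown sits.

The change replaces the aromatic ring with a non-aromatic ring and adds a hydrogen-bond donor and acceptor together, so the compounds shown cannot separate these features. From the compounds shown here alone, whether the step needs the amide remains open, and a plain cyclohexyl or a benzyl on the same nitrogen would test this.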